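Carbamate in place of ester on the chain end

The source may report more compounds than this note shows. Statements on the series, on what has been measured and on what is new or still open speak of the compounds shown alone.

Measured in an assay on H4 cells for inhibition of Fatty-acid amide hydrolase 1 (Homo sapiens); on this read-out lower numbers stand for stronger inhibition and higher numbers for weaker inhibition:
compound 1 `CCOC(=O)CC(CC)CCCCCn1c(C)nc(-c2ccccc2)c1-c1ccccc1` gives 9900 nM
compound 2 `CCOC(=O)CC(CCCCCn1c(C)nc(-c2ccccc2)c1-c1ccccc1)C(C)C` gives > 100000 nM
compound 3 `Cc1nc(-c2ccccc2)c(-c2ccccc2)n1CCCCCCNC(=O)Oc1ccccc1` gives 5.3 nM

The value of compound 2 is a limit of this assay, not a number. Compound 1 stands as the highest of the two numbers; its nearest neighbour is compound 3, with a 1900-fold lower number from compound 1 to compound 3 (3.27 log units; beyond the scatter). Compound 4 `CCC(CCCCCn1c(C)nc(-c2ccccc2)c1-c1ccccc1)NC(=O)Oc1ccccc1F` differs from compound 1 by ((2-fluorophenoxy)carbonyl)amino in place of (ethoxycarbonyl)methyl on a saturated chain carbon bound to two saturated chain carbons. Among the compounds with values here, two measured steps bear on it. The exchange of the ester-bearing side chain for a phenyl carbamate gave a 1900-fold lower number from compound 1 to compound 3 (3.27 log units; beyond the scatter), a large gain. Added branching on the chain carbon gave an at least 10-fold higher number from compound 1 to compound 2 (1.00 log units; beyond the scatter), a loss of at least modest size, with compound 2 sitting at the limit of > 100000 nM in this assay, at which 1 of the 3 values shown sits. Compound 4 carries the carbamate of compound 3 but keeps a branch on the saturated chain carbon, so a large fall in this assay is expected, somewhat short of that seen for compound 3. For compound 4 the estimate is 40 nM, between 5 nM and 400 nM, meaning an expected 250-fold lower number from compound 1 to compound 4 (2.39 log units; beyond the scatter).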

Compound 4, half-maximal inhibitory concentration: 30 nM
Compound 4: middle estimate off by 1.3-fold (0.12 log units), on the high side; low and high end bracket the measured number.
By their numbers in this assay, from the lowest: compound 3; then compound 4; then compound 1. At a limit, above all of these: compound 2.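

In this assay the carbamate keeps most of its gain when it stands directly on the saturated chain carbon bound to two saturated chain carbons, with the ethyl branch of compound 1 still in place (a 330-fold lower number from compound 1 to compound 4 (2.52 log units; beyond the scatter)). A large gain therefore does not depend on the unbranched chain of compound 3, and a branched chain can carry high inhibition once the ester is gone. Nothing measured here gives a cause for this gain.

The exchange brings in the carbamate nitrogen, the aromatic ring and the fluorine together, so their shares cannot be separated, and compound 4 differs from compound 3 in more than one place. Going by these compounds, how a urea in place of the carbamate, or an unsubstituted phenyl carbamate on this branched carbon, would compare remains open.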